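The compounds below may be only part of what the source reports. "The series", "measured", "known", "first", "only" and "open" are said of these compounds alone.

Measured so far in a functional assay on CCRF-CEM cells (Homo sapiens) for inhibition, read by MTT assay, with a stated time of 2 days, tested at 10 uM; a higher number here means more inhibition at the concentration tested (going by the name of the read-out), a lower number less inhibition: compound 1 `COC(=O)c1cc(-n2cc(-c3cc(O)ccc3O)nn2)ccc1O` gives 52%; compound 2 `COc1ccccc1-c1cn(-c2ccc(O)c(C(=O)Nc3cccc(C(F)(F)F)c3)c2)nn1` gives 65%; compound 3 `COC(=O)c1cc(-n2cc(-c3cccc(O)c3)nn2)ccc1O` gives 5%.

Compound 3 stands lowest of the three, with the step of a number 47 percentage points lower from compound 1 to compound 3 (beyond the scatter) separating it from compound 1 and a still wider gap to compound 2. Compound 4 `COC(=O)c1cc(-n2cc(-c3ccccc3OC)nn2)ccc1O` is the next to be measured. It differs from compound 3 by 2-methoxyphenyl in place of 3-hydroxyphenyl on an aromatic carbon. For the measured compounds named here, the only measured step that touches this position, a number 47 percentage points lower from compound 1 to compound 3 (beyond the scatter), concerns loss of a hydroxy, and compound 4 also carries no hydroxy on this ring. Going by the values given here, compound 2 bears a 2-methoxyphenyl on a different core and gives 65%, but no single-change step links it to compound 4. Expectation for compound 4: a step of a number 10 percentage points higher from compound 3 to compound 4 (within the scatter), small and within the scatter. The estimate for compound 4 is 15%, range 0% to 45%.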

Compound 4, a percentage reported as inhibition, at one concentration (the size of the read-out at that concentration, not a potency): 6%
Compound 4: middle estimate off by 9 percentage points, on the high side; low and high end bracket the measured number.
By their numbers in this assay, from the lowest: compounds 3 and 4 (each within the scatter of the next); then compound 1; then compound 2.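

In this assay, a number 1 percentage points higher from compound 3 to compound 4 (within the scatter), so on this aromatic carbon of the shared core, 2-methoxyphenyl and 3-hydroxyphenyl are not told apart, and neither matches 2,5-dihydroxyphenyl, as a number 46 percentage points lower from compound 1 to compound 4 (beyond the scatter) shows. With 2-methoxyphenyl held fixed, the carbonyl substituent carries a large step, a number 59 percentage points lower from compound 2 to compound 4 (beyond the scatter), so this aryl group gives a high number only alongside (3-(trifluoromethyl)phenyl)amino. No measurement at hand explains either result. Open, as far as these compounds go, is whether an amine or a carboxylic acid on this ring behaves like 2,5-dihydroxyphenyl, and whether 2,5-dihydroxyphenyl and (3-(trifluoromethyl)phenyl)amino add up in one compound.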